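Ester Variation on a Piperazine-Linked Purine Thioether Series

This account rests on a few compounds, and the source may have more. Where it says the series, first, only, none or still open, it means among the compounds named here.

Three compounds have been measured so far:

Compound 1, `OC(CSc1[nH]cnc2ncnc1-2)CN1CCN(C(c2ccccc2)c2ccccc2)CC1`, in a functional assay on muscle tissue (Mustela putorius furo) (a lower number here means a smaller maximal response, a higher number a larger maximal response), gives 249%.
Compound 2, `COc1ccc(C(c2ccc(OC)cc2)N2CCN(CC(O)CSc3[nH]cnc4ncnc3-4)CC2)cc1`, in this assay gives 98%.
Compound 3, `CC(=O)OC(CSc1[nH]cnc2ncnc1-2)CN1CCN(C(c2ccc(F)cc2)c2ccc(F)cc2)CC1`, in this assay gives 248%.

Compound 3 stands second highest among these three numbers. Its nearest neighbour is compound 1, whose value lies within the usual scatter of the measurement, so the two cannot be told apart on these data. The furthest is compound 2, whose value lies far below that of compound 3, a gap well beyond the scatter.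

The next compound, compound 4, `CC(C)(C)C(=O)OC(CSc1[nH]cnc2ncnc1-2)CN1CCN(C(c2ccc(F)cc2)c2ccc(F)cc2)CC1`, is not yet measured. It differs from compound 3 in one place only: tert-butyl in place of methyl on a carbonyl carbon. The ester part of the molecule is made bulkier, while the rest of the structure, including the shared core and the bis(4-fluorophenyl)methyl piperazine, stays the same.

Among the measured compounds shown here, no pair of measured compounds shows the effect of such an ester change, so there is no direct guide. With nothing pointing to a loss, the step of a number 13 percentage points lower from compound 3 to compound 4 (beyond the scatter) is expected to stay within the scatter. Compound 4 is estimated to reach 235%, with a range from 160% to 300%.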

Compound 4, largest response reached (reported as maximum), in percent of the reference or control that the assay uses: 43%
Estimate against measurement, compound 4: 192 percentage points above; measured number below the stated range.
By their numbers in this assay, from the lowest: compound 4; then compound 2; then compounds 3 and 1 (each within the scatter of the next).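

In this assay, tert-butyl in place of methyl on a carbonyl carbon gives a number 205 percentage points lower from compound 3 to compound 4 (beyond the scatter). The change adds only carbon atoms and no hydrogen-bond donor, acceptor, ring or net charge, and the rest of the molecule stays the same, so this one step shows that the group on the ester carbonyl strongly affects the maximal response. The earlier compounds could not show this, since no two of them differed only at this place, and the data contain nothing that explains the step.

On these data alone, only methyl and tert-butyl can be compared at this carbonyl carbon, so it remains open whether an ethyl or isopropyl group would keep the high response of compound 3, fall to the low one of compound 4, or land in between. Also open, as far as these compounds go, is whether a phenyl group at this place, or an amide in place of the ester, would behave like either of them, and whether the same swap would have a similar effect with a different group on the piperazine.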